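Halogen swap on the core of compound 3

This account rests on a few compounds, and the source may have more. Where it says the series, first, only, none or still open, it means among the compounds named here.

Three thiol acids have been measured in an assay on isolated protein for inhibition of Calpain-1 catalytic subunit (Sus scrofa), read by FRET; a lower number here means a stronger inhibitor, a higher number a weaker inhibitor. Compound 1 `O=C(O)/C(S)=C/c1ccccc1Cl` gives 11900 nM, and compound 2 `O=C(O)/C(S)=C/c1ccccc1Br` gives 21000 nM. The change between them, (chloro in place of bromo on an aromatic carbon), made a 1.8-fold lower number from compound 2 to compound 1 (0.25 log units; within the scatter). Compound 3 `O=C(O)/C(S)=C/c1c[nH]c2c(Br)cccc12` gives 2 nM, the lowest of the three numbers; the difference between its core and the core of compound 2 is not broken down here. Compound 4 `O=C(O)/C(S)=C/c1c[nH]c2c(Cl)cccc12` is not yet measured; it differs from compound 3 by chloro in place of bromo on an aromatic carbon. This is the same kind of change as that from compound 2 to compound 1, though the place differs: there the halogen sat ortho to a group of 6 heavy atoms, here it sits on a ring that is part of a fused or bridged system of two rings, ortho to a fused ring and meta to a fused ring. Compound 4 is expected to give 1.5 nM, with a range from 0.5 nM to 6 nM. The expected step is a 1.3-fold lower number from compound 3 to compound 4 (0.12 log units; within the scatter), which rests on compound 1 and compound 2, where the step was a 1.8-fold lower number from compound 2 to compound 1 (0.25 log units; within the scatter).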

Compound 4, half-maximal inhibitory concentration: 10 nM
The estimate for compound 4 lay 6.7-fold (0.82 log units) below the measured number, and the stated range ends below it.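

In this assay, chloro in place of bromo on the core of compound 3 gave a 5.0-fold higher number from compound 3 to compound 4 (0.70 log units; beyond the scatter). The same change on the core of compound 2 gave a different result, so in this series the step read on one core did not carry over to the other: the same change on two cores in this assay, a 1.8-fold lower number (0.25 log units; within the scatter) from compound 2 to compound 1 and a 5.0-fold higher number (0.70 log units; beyond the scatter) from compound 3 to compound 4, 8.8-fold (0.95 log units) apart, beyond the scatter of two such steps This shows that the size of the step depended on the core in this one comparison, but it does not show which part of the core matters or why, and two cores give no rule for predicting the step on a third.

The compounds shown leave open whether other groups at the same place, such as fluoro, methyl or an amine, would stay close to chloro and bromo on either core. On these data alone, all four compounds also share the thiol acid, so the effect of an ester in place of the carboxylic acid remains open.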